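Halogen at the aryl ether ring: from compound 3 to compound 4

A few compounds are considered here, and "the series" means these few. Any claim that something is new, unique, unknown or untested is made for them only; others in the source may bear on it.

Measured compounds in an assay on HEK-293T cells for antagonist activity at vitamin D3 receptor (Homo sapiens), read by a luciferase reporter, with a stated time of 24 h; a higher number here means a weaker inhibitor, a lower number a stronger inhibitor:
compound 1 `CC(C)c1onc(-c2c(Cl)cccc2Cl)c1COc1ccc(-c2nc3ccc(C(=O)O)cc3n2CC2CCCCC2)c(F)c1` gives 840 nM
compound 2 `CC(C)c1onc(-c2c(Cl)cccc2Cl)c1COc1ccc(-c2nc3ccc(C(=O)O)cc3n2CC2CC2)cc1` gives 2650 nM
compound 3 `CC(C)c1onc(-c2c(Cl)cccc2Cl)c1COc1ccc(-c2nc3ccc(C(=O)O)cc3n2CC2CCCCC2)cc1` gives 346 nM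

Compound 3 carries the lowest number of the three. The two measured steps toward it are a 2.4-fold lower number from compound 1 to compound 3 (0.39 log units; beyond the scatter) and a 7.7-fold lower number from compound 2 to compound 3 (0.88 log units; beyond the scatter), both modest and both beyond the scatter.

Compound 4 `CC(C)c1onc(-c2c(Cl)cccc2Cl)c1COc1ccc(-c2nc3ccc(C(=O)O)cc3n2CC2CCCCC2)c(Cl)c1` differs from compound 3 by chloro in place of hydrogen on an aromatic carbon. Among the compounds with values here, only one measured step bears on this change: a 2.4-fold lower number from compound 1 to compound 3 (0.39 log units; beyond the scatter), which concerned fluoro on the same aromatic carbon. A second halogen at that carbon is expected to move the number in the same direction, possibly a little further, so the expected step is a 2.6-fold higher number from compound 3 to compound 4 (0.42 log units; beyond the scatter). Compound 4 is therefore estimated at 900 nM in this assay, with a range from 350 nM to 2500 nM.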

Compound 4, half-maximal inhibitory concentration: 160 nM
Beside the measured number, compound 4's estimate is 5.6-fold (0.75 log units) above it; measured number outside the range, below it.
By their numbers in this assay, from the lowest: compound 4; then compound 3; then compound 1; then compound 2.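

In this assay the direction of the step at this aromatic carbon depends on the halogen: chloro in place of hydrogen lowers the number (a 2.2-fold lower number from compound 3 to compound 4 (0.33 log units; beyond the scatter)), whereas fluoro there raised it relative to hydrogen (a 2.4-fold lower number from compound 1 to compound 3 (0.39 log units; beyond the scatter)). The direct exchange of fluoro for chloro gives the larger step (a 5.3-fold lower number from compound 1 to compound 4 (0.72 log units; beyond the scatter)), so the earlier fluoro result does not carry over to chloro. No measurement at hand accounts for this difference between the two halogens.

On these data alone, whether bromo or methyl at this carbon would follow chloro or fluoro remains open. Also open, as far as these compounds go, is whether chloro lowers the number when cyclopropyl replaces cyclohexyl on the shared core.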